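This account rests on a few compounds, and the source may have more. Where it says the series, first, only, none or still open, it means among the compounds named here.

Compounds measured so far:
Compound 1 `OC[C@H]1O[C@@H](n2cnc3c(NCc4ccc(Cl)cc4)ncnc32)[C@H](O)[C@@H]1O`: > 166000 nM
Compound 2 `Cc1ccc(CNc2ncnc3c2ncn3[C@@H]2O[C@H](CO)[C@@H](O)[C@H]2O)cc1`: "not determined" (no result reported)
Compound 3 `COc1ccc(CNc2ncnc3c2ncn3[C@@H]2O[C@H](CO)[C@@H](O)[C@H]2O)c(OC)c1`: "not determined" (no result reported)

All three compounds were taken into a functional assay on G-361 cells (Homo sapiens) for antiproliferative activity, with a stated time of 72 h (a lower number here means a stronger inhibitor, a higher number a weaker inhibitor), but the results give little to work with. Compound 3 has no number, its entry reading "not determined" (no result reported). Compound 2 is in the same position, with the entry "not determined" (no result reported). Compound 1 gives > 166000 nM, which is a limit and not a number.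

Compound 4 `OC[C@H]1O[C@@H](n2cnc3c(NCc4ccc(F)c(F)c4F)ncnc32)[C@H](O)[C@@H]1O` has yet to be measured in this assay. It carries 2,3,4-trifluorophenyl in place of 2,4-dimethoxyphenyl on a saturated chain carbon bound to a nitrogen on an aromatic ring.

Compound 3 offers no starting value, so the size of this step in this assay cannot be read from it. The only anchor is the limit of > 166000 nM in this assay, at which 1 of the 3 values shown sits. Against that limit of compound 1, a moderate move towards stronger inhibition is expected, and a reading that again stops at the limit remains quite possible. For compound 4 the estimated half-maximal inhibitory concentration is 30000 nM, with an expected range from 3000 nM to 166000 nM.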

Compound 4, half-maximal inhibitory concentration: > 166000 nM
Compound 4 was reported as a limit; the forecaster's own chance of this, stated with the estimate: 35%; middle value at least 5.5-fold (0.74 log units) away from the limit.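

In this assay compound 4 gives > 166000 nM, which is a limit and not a number. For the compounds shown here, compound 1 gives > 166000 nM, also a limit, so no step between compound 1 and compound 4 can be read. The compounds shown leave open whether changing the aryl group alters the antiproliferative activity at all, as the readable results end at one value: the limit of > 166000 nM in this assay, at which 2 of the 4 values shown sit.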